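A Dimethylamino for Methoxy Swap in a Cytotoxicity Screen

A few compounds are considered here, and "the series" means these few. Any claim that something is new, unique, unknown or untested is made for them only; others in the source may bear on it.

Three compounds were tested in a toxicity assay on MDCK cells (Canis lupus familiaris) for cytotoxicity, read by crystal violet staining, with a stated time of 48 h; on this read-out lower numbers stand for higher toxicity in this test and higher numbers for lower toxicity in this test. Compound 1 `Cc1ccc2cc(CN(Cc3ccc(F)cc3)Cc3ccc(C(C)C)cc3)c(=O)[nH]c2c1` returned only a limit of > 33000 nM in this assay. Compound 2 `Cc1ccc2[nH]c(=O)c(CN(Cc3ccc(F)cc3)Cc3ccc(-c4ccccc4)cc3)cc2c1` likewise gave only a limit, > 5000 nM. Compound 3 `COc1ccc(CN(Cc2ccc(C(C)(C)C)cc2)Cc2cc3cc(C)ccc3[nH]c2=O)cc1` also reached just a limit, > 10000 nM, and so sits at the limit of > 10000 nM in this assay, at which 1 of the 3 values shown sits. Going by the values given here, none of the three therefore yields a true number, and no step between measured compounds can be drawn. Compound 4 `Cc1ccc2[nH]c(=O)c(CN(Cc3ccc(N(C)C)cc3)Cc3ccc(C(C)(C)C)cc3)cc2c1` differs from compound 3 by dimethylamino in place of methoxy on an aromatic carbon. Among the compounds with values here, with no measured step to lean on, the change is expected to stay within the usual scatter of this assay, with no direction assignable. The step that the limit leaves unreadable from compound 3 to compound 4 is accordingly expected to be small. Compound 4 is estimated at 20000 nM, within 8000 nM to 60000 nM, most likely again reported only as a limit.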

Compound 4, half-maximal cytotoxic concentration: > 5000 nM
Compound 4: a limit, no number (the forecaster's own chance of this, stated with the estimate: 80%); the middle value lies beyond the limit too.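

Compound 3 and compound 4 both stand only as limits in this assay, so no step can be read between them. The compounds shown leave open where any true half-maximal cytotoxic concentration lies, and whether dimethylamino in place of methoxy changes it.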